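Chloro added to the urea aryl: note on compound 4

The source may report more compounds than this note shows. Statements on the series, on what has been measured and on what is new or still open speak of the compounds shown alone.

Measured so far in a functional assay on DU-145 cells (Homo sapiens) for inhibition, read by sulforhodamine B assay, with a stated time of 48 h; on this read-out lower numbers stand for stronger inhibition of growth and higher numbers for weaker inhibition of growth:
compound 1, `COc1cc(-c2nn(-c3cccc(NC(=O)c4cccc(C(F)(F)F)c4)c3)cc2-c2ccncc2)ccc1Cl`, gives 1760 nM
compound 2, `COc1cc(-c2nn(-c3cccc(NC(=O)Nc4ccc(Cl)c(Cl)c4)c3)cc2-c2ccncc2)ccc1Cl`, gives 1520 nM
compound 3, `COc1cc(-c2nn(-c3cccc(NC(=O)Nc4cccc(C(F)(F)F)c4)c3)cc2-c2ccncc2)ccc1Cl`, gives 1670 nM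

The three numbers sit in one band. Compound 3 stands among them with nothing to separate it from its neighbours: the steps of a 1.1-fold lower number from compound 1 to compound 3 (0.02 log units; within the scatter) and a 1.1-fold higher number from compound 2 to compound 3 (0.04 log units; within the scatter) are both within the scatter, as is a 1.2-fold lower number from compound 1 to compound 2 (0.06 log units; within the scatter), so exchanging the amide for either urea, or one urea aryl for the other, has left this assay unmoved.

Compound 4, `COc1cc(-c2nn(-c3cccc(NC(=O)Nc4ccc(Cl)c(C(F)(F)F)c4)c3)cc2-c2ccncc2)ccc1Cl`, is the next member. It differs from compound 3 by chloro in place of hydrogen on an aromatic carbon. The step that bears on it most directly is a 1.1-fold higher number from compound 2 to compound 3 (0.04 log units; within the scatter), where the 3,4-dichlorophenyl and the 3-(trifluoromethyl)phenyl ureas gave the same number within scatter; compound 4 carries both a chloro and a trifluoromethyl on that ring and so lies between those two patterns. The amide-to-urea steps a 1.2-fold lower number from compound 1 to compound 2 (0.06 log units; within the scatter) and a 1.1-fold lower number from compound 1 to compound 3 (0.02 log units; within the scatter) likewise showed no movement.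

No step beyond the scatter is therefore expected from compound 3 to compound 4, that is a 1.0-fold lower number from compound 3 to compound 4 (0.02 log units; within the scatter). Compound 4 is estimated at 1600 nM in this assay, with a range of 800 nM to 3200 nM.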

Compound 4, concentration for 50% growth inhibition: 1500 nM
The estimate for compound 4 lay 1.1-fold (0.03 log units) above the measured number; measured number inside the range.
By their numbers in this assay, from the lowest: compounds 4, 2, 3 and 1 (each within the scatter of the next).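

In this assay, among the compounds shown here, chloro in place of hydrogen, on the aromatic carbon ortho to the trifluoromethyl group and para to a large group, gives a 1.1-fold lower number from compound 3 to compound 4 (0.05 log units; within the scatter) and so provides the first direct reading at this position: the ring carries the added chloro with no change beyond the scatter. The 4-chloro-3-(trifluoromethyl)phenyl urea also stands level with the 3,4-dichlorophenyl urea, with a 1.0-fold lower number from compound 2 to compound 4 (0.01 log units; within the scatter) for trifluoromethyl in place of chloro, and level with the amide of the series, with a 1.2-fold lower number from compound 1 to compound 4 (0.07 log units; within the scatter) for the change on the carbonyl carbon, so this more substituted ring does not separate from the other three compounds. No measurement is available that accounts for this flat reading.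

The urea aryl groups shown carry only chloro and trifluoromethyl, so it remains open whether a methoxy, a dimethylamino or a carboxylic acid at this position would move the number beyond the scatter. Going by these compounds, it also remains open whether chloro at this position reads the same on the amide of compound 1.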